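The compounds below may be only part of what the source reports. "The series", "measured", "known", "first", "only" and "open" are said of these compounds alone.

Measured so far in a functional assay on MT4 cells (Homo sapiens) for cytotoxicity, read by MTT assay; on this read-out lower numbers stand for higher toxicity in this test and higher numbers for lower toxicity in this test:
- compound 1 `COc1ccc(Sc2nc(O)c(C)c(Cc3c(Cl)cccc3Cl)n2)cc1`: > 61400 nM (a limit)
- compound 2 `Cc1c(O)nc(Sc2ccccc2)nc1Cc1c(Cl)cccc1Cl`: > 66300 nM (a limit)

Compound 2 stands only at a limit, > 66300 nM. Compound 1 likewise gives only a limit, > 61400 nM. Going by the values given here, the one measured step is a step that the two limits leave unreadable from compound 1 to compound 2, so it offers no size to carry forward. Compound 3 `Cc1c(O)nc(Sc2ccc(F)cc2F)nc1Cc1c(Cl)cccc1Cl` has 2,4-difluorophenyl in place of phenyl on a sulfur. With no readable step to go on, no change beyond the scatter is expected in this assay. The expected step is an at least 1.1-fold lower number from compound 2 to compound 3 (0.04 log units; that floor lies within the scatter). For compound 3 the estimate is 60000 nM, with an expected range of 25000 nM to 120000 nM.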

Compound 3, half-maximal cytotoxic concentration: > 60500 nM
Compound 3: no number, only a limit; the forecaster's own chance of this, stated with the estimate: 75%; middle value at least 1.0-fold (0.00 log units) from the limit.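

In this assay compound 3 gives only a limit, > 60500 nM. Going by these compounds alone, no step among compound 1, compound 2 and compound 3 can be read. The concentration at which any of these compounds becomes toxic to the cells remains open.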